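The compounds below may be only part of what the source reports. "The series", "measured", "known", "first", "only" and "open" are said of these compounds alone.

Measured compounds:
compound 1 `CCCCc1ccccc1N1CCN(CCCCCC(=O)NC2CCCc3ccccc32)CC1` — 2810 nM
compound 2 `Nc1ccccc1N1CCN(CCCCCC(=O)NC2CCCc3ccccc32)CC1` — 8180 nM

In an assay on HEK293 cells for displacement of a labelled ligand from 5-hydroxytryptamine receptor 7 (Rattus norvegicus) (on this read-out higher numbers stand for weaker inhibition and lower numbers for stronger inhibition), compound 1 gives 2810 nM. Compound 2 shows the higher of the two numbers, with 8180 nM in this assay, so it is the weaker of the pair. Going by the values given here, the only measured step is a 2.9-fold higher number from compound 1 to compound 2 (0.46 log units; beyond the scatter), a change on the aromatic ring that sits on the ring nitrogen of the shared core.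

Compound 3 `O=C(CCCCCN1CCN(c2ccccn2)CC1)NC1CCCc2ccccc21` has not yet been measured. It differs from compound 2 in one place: pyridin-2-yl in place of 2-aminophenyl on an amine nitrogen in a ring. Among the compounds with values here, no measured step changes this ring itself; the step from compound 1 to compound 2 only swapped a group on that ring, and its modest size gives little guidance for a swap of the whole ring. What remains is that both measured compounds carry a large, unmodified aromatic ring here, and that the two numbers differ only modestly, so the new ring is expected to land in the same broad region. The estimate for compound 3 in this assay is 4000 nM, with a range from 1000 nM to 16000 nM, which means an expected step of a 2.0-fold lower number from compound 2 to compound 3 (0.31 log units; beyond the scatter).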

Compound 3, inhibition constant: 278 nM
Beside the measured number, compound 3's estimate is 14-fold (1.16 log units) above it; the measured number lies below the stated range.
By their numbers in this assay, from the lowest: compound 3; then compound 1; then compound 2.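

The new result shows that, in this assay, this position responds far more to replacing the whole aromatic ring on the amine nitrogen than the earlier swap of a group on that ring suggested, which was only a 2.9-fold higher number from compound 1 to compound 2 (0.46 log units; beyond the scatter). Pyridin-2-yl in place of 2-aminophenyl gives a 29-fold lower number from compound 2 to compound 3 (1.47 log units; beyond the scatter), and pyridin-2-yl in place of 2-butylphenyl gives a 10-fold lower number from compound 1 to compound 3 (1.00 log units; beyond the scatter), so compound 3 now has the lowest number of the three, and a large aromatic ring at this position does not by itself fix the number within one narrow region. Nothing available here explains why the number falls so far.

The change makes two alterations at once, since a ring nitrogen enters and the group on the ring leaves, and these compounds cannot show which of the two accounts for the drop. A plain phenyl ring at this position would help to separate them, while pyrimidin-2-yl, with a further ring nitrogen, or a methyl group on the pyridine ring would test how far the effect of the new ring extends.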